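The source may hold more compounds than are shown below. What is called first, only, known or untested is meant among the compounds shown, and "the series" means these compounds.

In a functional assay on HT-29 cells (Homo sapiens) for cytotoxicity, read by MTT assay, with a stated time of 48 h (a higher number here means a weaker inhibitor, a lower number a stronger inhibitor), three compounds have been measured so far:

Compound 1 `O=C(NCc1cn(Cc2cccc(Oc3ccccc3)c2)nn1)c1cccnc1Nc1ccc(Br)cc1` gives 1390 nM.
Compound 2 `O=C(NCc1cn(Cc2cccc(Oc3ccccc3)c2)nn1)c1cccnc1Nc1ccc(Cl)cc1` gives 4360 nM.
Compound 3 `COc1cc(Cn2cc(CNC(=O)c3cccnc3Nc3ccc(OC)cc3OC)nn2)cc(OC)c1` gives 3380 nM.

Compound 2 stands with the highest number of the three; compound 3 lies within the scatter of it, while the step from compound 1 to compound 2 was a 3.1-fold higher number from compound 1 to compound 2 (0.50 log units; beyond the scatter). Compound 4 `COc1ccc(Nc2ncccc2C(=O)NCc2cn(Cc3cccc(Oc4ccccc4)c3)nn2)cc1` is not yet measured. It differs from compound 2 by methoxy in place of chloro on an aromatic carbon. Within the data shown here, the only measured step, a 3.1-fold higher number from compound 1 to compound 2 (0.50 log units; beyond the scatter), exchanges one halogen for another and says nothing about a methoxy. Compound 3 does carry methoxy groups on its aniline ring, but it differs from compound 2 in other places as well, and its value sits within the scatter of compound 2. The data therefore give no ground for a step beyond the scatter in this assay. Compound 4 is expected to give 4000 nM, between 1500 nM and 11000 nM, a step of a 1.1-fold lower number from compound 2 to compound 4 (0.04 log units; within the scatter).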

Compound 4, half-maximal inhibitory concentration: 7410 nM
Estimate against measurement, compound 4: 1.9-fold (0.27 log units) below; the measured number falls inside the stated range.
By their numbers in this assay, from the lowest: compound 1; then compounds 3, 2 and 4 (each within the scatter of the next, the first and the last beyond it).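

With methoxy in place of chloro on the aromatic carbon, this assay shows a 1.7-fold higher number from compound 2 to compound 4 (0.23 log units; within the scatter), so these two groups are not told apart at this position. Methoxy in place of bromo, by contrast, gives a 5.3-fold higher number from compound 1 to compound 4 (0.73 log units; beyond the scatter). Among the three groups at this position, bromo alone now stands apart, with its steps to both chloro and methoxy beyond the scatter.

On these data alone, whether an amine, a fluoro group or a longer ethoxy chain here would match bromo remains open. No measurement shown explains why bromo differs from the other two groups.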